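This account rests on a few compounds, and the source may have more. Where it says the series, first, only, none or still open, it means among the compounds named here.

Three compounds built on a shared two-ring core were tested in an assay on isolated protein for inhibition of protein kinase C zeta type (Homo sapiens), read by mobility shift assay, tested at 30 uM; on this read-out higher numbers stand for more inhibition at the one concentration tested (going by the name of the read-out) and lower numbers for less inhibition. Compound 1, `Cc1cc2[nH]nc(N)c2c(=O)[nH]1`, gives 10% in this assay. Compound 2, `CC(C)(C)c1cc2[nH]nc(N)c2c(=O)[nH]1`, carries tert-butyl in place of methyl on an aromatic carbon relative to compound 1, and in this assay compound 2 gives -9%. The step between them is a number 19 percentage points lower from compound 1 to compound 2 (beyond the scatter). Compound 3, `Cc1cc2nn(-c3ccccc3)c(N)c2c(=O)[nH]1`, has a core that differs from that of compound 1 in more than one place; the difference between the two cores is not broken down here. In this assay compound 3 gives -49%, the lowest of the three numbers, separated from compound 2 and compound 1 by gaps that both lie beyond the scatter.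

Compound 4, `CC(C)(C)c1cc2nn(-c3ccccc3)c(N)c2c(=O)[nH]1`, has not yet been measured in this assay. It differs from compound 3 by tert-butyl in place of methyl on an aromatic carbon. Among the measured compounds shown here, this is the same change that turns compound 1 into compound 2, and it sits at the same place on the ring, so the earlier pair is the only guide available. That earlier step, a number 19 percentage points lower from compound 1 to compound 2 (beyond the scatter), was modest and beyond the scatter. Compound 4 is therefore expected to show a step of about a number 11 percentage points lower from compound 3 to compound 4 (beyond the scatter). Since the starting number for compound 3 is already far below zero, the read-out is expected to stay well into negative territory. The estimate for compound 4 in this assay is -60%, with a likely range from -85% to -30%.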

Compound 4, a percentage reported as inhibition, at one concentration (the size of the read-out at that concentration, not a potency): -1%
The estimate for compound 4 lay 59 percentage points below the measured number; the measured number lies above the stated range.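

In this assay, putting tert-butyl in place of methyl on an aromatic carbon of the core of compound 3 gives a number 48 percentage points higher from compound 3 to compound 4 (beyond the scatter), and the same change at the same place on the core of compound 1 moved the number the other way: the same change on two cores in this assay, a number 19 percentage points lower (beyond the scatter) from compound 1 to compound 2 and a number 48 percentage points higher (beyond the scatter) from compound 3 to compound 4, 67 percentage points apart, beyond the scatter of two such steps Across these two pairs, then, the step seen on one core did not carry over to the other in either size or direction, so the earlier pair could not serve as a guide to the later one, and no single effect of this change can be stated for the series. What this does not show is which difference between the two cores goes with the reversal, as they differ in more than one place and each direction rests on one pair of compounds read at a single concentration, which gives no potency.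

The compounds shown carry only methyl or tert-butyl at this aromatic carbon, so it stays open how ethyl, isopropyl, an amine or a carboxylic acid there would behave on either core. As far as these compounds go, whether a third core would follow the step of compound 1 to compound 2, that of compound 3 to compound 4, or neither also stays open.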